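The compounds below may be only part of what the source reports. "The series", "measured", "known", "first", "only" and "open" are said of these compounds alone.

- Compound 1 `CCCC(CCO)n1cnc2c(Cl)nc(F)nc21`: 17200 nM
- Compound 2 `CCCCCC(CCO)n1cnc2c(Cl)nc(F)nc21`: 7440 nM

Within the data shown here, in a functional assay on SW480 cells (Homo sapiens) for antiproliferative activity, read by MTT assay, with a stated time of 48 h (a higher number here means a weaker inhibitor, a lower number a stronger inhibitor), compound 2 gives 7440 nM, the lower of the two numbers so far. Compound 3 `CCCCCCC(CCO)n1cnc2c(Cl)nc(F)nc21` differs from compound 2 by a single change, (methyl in place of hydrogen on a saturated chain carbon, six bonds along the chain from an aromatic nitrogen). Among the measured compounds shown here, only one measured step bears on this: a 2.3-fold lower number from compound 1 to compound 2 (0.36 log units; beyond the scatter), which came with ethyl in place of hydrogen on the chain. Compound 3 gains only methyl, so a smaller step in the same direction is expected, possibly not beyond the scatter. The expected change is a 1.5-fold lower number from compound 2 to compound 3 (0.17 log units; within the scatter). For compound 3 the estimated value is 5000 nM, with an expected range of 2600 nM to 9500 nM.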

Compound 3, half-maximal inhibitory concentration: 12900 nM
Compound 3: middle estimate off by 2.6-fold (0.41 log units), on the low side; the measured number lies above the stated range.
By their numbers in this assay, from the lowest: compounds 2, 3 and 1 (each within the scatter of the next, the first and the last beyond it).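

In this assay, methyl in place of hydrogen at this chain carbon gives a 1.7-fold higher number from compound 2 to compound 3 (0.24 log units; within the scatter) and, measured from the shortest chain, propyl in place of hydrogen gives a 1.3-fold lower number from compound 1 to compound 3 (0.12 log units; within the scatter) so neither step can be read as a real change. Compound 3 therefore cannot be told apart from compound 1 or compound 2, and the drop seen with ethyl does not continue with this added methyl. Nothing measured here explains this result.

On these data alone, whether a longer chain, or an amine or carboxylic acid in place of this methyl, would move the number beyond the scatter stays open.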